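The compounds below may be only part of what the source reports. "The series", "measured", "known", "first", "only" and "open" are said of these compounds alone.

Among the measured compounds shown here, compound 2 `O=C(NCc1cccc(Cn2cnc3ccccc32)c1)c1nc2ccccc2[nH]1` carries a 1H-benzimidazol-2-yl group on the carbonyl carbon, and in an assay for inhibition of Indoleamine 2,3-dioxygenase 1 (Homo sapiens), read by HPLC, with a stated time of 48 h (a higher number here means a weaker inhibitor, a lower number a stronger inhibitor), compound 2 gives 407 nM, the lowest of the three numbers measured so far. Compound 1 `Cc1ccc2[nH]c(C(=O)NCc3cccc(Cn4cnc5ccccc54)c3)cc2c1`, with 5-methyl-1H-indol-2-yl in that position, gives 636 nM in this assay, and a 1.6-fold lower number from compound 1 to compound 2 (0.19 log units; within the scatter). Compound 3 `O=C(NCc1cccc(Cn2cnc3ccccc32)c1)c1ccc(F)cc1`, with 4-fluorophenyl in that position, gives 961 nM in this assay; here a 1.5-fold higher number from compound 1 to compound 3 (0.18 log units; within the scatter), while a 2.4-fold higher number from compound 2 to compound 3 (0.37 log units; beyond the scatter). Compound 4 `N#Cc1ccc(C(=O)NCc2cccc(Cn3cnc4ccccc43)c2)cc1` has not yet been measured in this assay; its change from compound 2 is 4-cyanophenyl in place of 1H-benzimidazol-2-yl on a carbonyl carbon. The step that bears on it most directly is a 2.4-fold higher number from compound 2 to compound 3 (0.37 log units; beyond the scatter), which likewise removes the 1H-benzimidazol-2-yl group in favour of a substituted phenyl; the step of a 1.5-fold higher number from compound 1 to compound 3 (0.18 log units; within the scatter) points the same way but stays within the scatter. For compound 4 the expected step is therefore a 2.1-fold higher number from compound 2 to compound 4 (0.32 log units; beyond the scatter), a modestly higher number in this assay. Compound 4 is thus estimated to give 850 nM in this assay, within a range of 300 nM to 2500 nM.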

Compound 4, half-maximal inhibitory concentration: 90 nM
For compound 4 the middle estimate is 9.4-fold (0.98 log units) above the measured one; the measured number lies below the stated range.
By their numbers in this assay, from the lowest: compound 4; then compounds 2, 1 and 3 (each within the scatter of the next, the first and the last beyond it).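

In this assay, cyano in place of fluoro on an aromatic carbon gives an 11-fold lower number from compound 3 to compound 4 (1.03 log units; beyond the scatter) and shows that, with a phenyl ring on the carbonyl carbon, a single substituent can decide the outcome. The 4-cyanophenyl group also gives a 4.5-fold lower number from compound 2 to compound 4 (0.66 log units; beyond the scatter) and a 7.1-fold lower number from compound 1 to compound 4 (0.85 log units; beyond the scatter) and so shows that losing the 1H-benzimidazol-2-yl group need not raise the number, as compound 3 alone had suggested. Nothing given here accounts for this result.

Going by these compounds, whether an amine, a carboxylic acid or a methoxy group in place of the cyano group would give a number like that of compound 4 remains open. On these data alone, it also remains open whether the 4-cyanophenyl group would keep its advantage if the shared core were changed.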